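A Fluorine on the Benzyl Group of Compound 2

The source may hold more compounds than are shown below. What is called first, only, known or untested is meant among the compounds shown, and "the series" means these compounds.

Compound 2 `c1ccc(Cn2cnc3c(Sc4ccccc4)ncnc32)cc1` has the lower of the two numbers measured in an assay on isolated protein for inhibition of Rho-associated protein kinase 1 (Homo sapiens), tested at 30 uM; a lower number here means less inhibition, a higher number more inhibition at the concentration tested (going by the name of the read-out): compound 2 gives 1%, whereas compound 1 `c1ccc(Sc2ncnc3[nH]cnc23)cc1` gives 33%. Among the compounds with values here, the only measured step, a number 32 percentage points lower from compound 1 to compound 2 (beyond the scatter), concerns a different change and therefore offers no direct guide. Compound 3 `Fc1ccc(Cn2cnc3c(Sc4ccccc4)ncnc32)cc1` differs from compound 2 by fluoro in place of hydrogen on an aromatic carbon. No comparable change has been measured here, so the step for compound 3 is expected to be a number 2 percentage points higher from compound 2 to compound 3 (within the scatter), nothing beyond the scatter. Compound 3 is estimated at 3%, within a range from -5% to 15%.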

Compound 3, a percentage reported as inhibition, at one concentration (the size of the read-out at that concentration, not a potency): 2%
For compound 3 the middle estimate is 1 percentage points above the measured one; the measured number falls inside the stated range.
By their numbers in this assay, from the lowest: compounds 2 and 3 (each within the scatter of the next); then compound 1.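

In this assay, fluoro in place of hydrogen on an aromatic carbon, para to a large group, gives a number 1 percentage points higher from compound 2 to compound 3 (within the scatter) and so does not separate compound 3 from compound 2. Set against the unsubstituted nitrogen, 4-fluorobenzyl in place of hydrogen gives a number 31 percentage points lower from compound 1 to compound 3 (beyond the scatter) and so, like benzyl, stays far under compound 1. Nothing on hand offers a reason for either step.

From the compounds shown here alone, whether an amine or a carboxylic acid at that ring position would move the number remains open. So does whether a longer chain in place of benzyl on the nitrogen would bring it nearer to compound 1.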